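The source may report more compounds than this note shows. Statements on the series, on what has been measured and on what is new or still open speak of the compounds shown alone.

Compound 1 `Nc1ncn(CCC2(N)OC(=O)C(OCc3ccccc3)=C2OCc2ccccc2)c(=O)n1` shows in an ADME assay on WI-38 cells (Homo sapiens) for inhibition, read by MTT assay, with a stated time of 72 h (a lower number here means a stronger inhibitor, a higher number a weaker inhibitor), only a limit of the assay, > 100000 nM, not a number. Compound 1 thus sits at the limit of > 100000 nM in this assay, at which 1 of the 2 values shown sits. Compound 2 `O=C1O/C(=C\Cn2ncc(=O)[nH]c2=O)C(OCc2ccccc2)=C1OCc1ccccc1` gives in this assay 24600 nM and is the only number shown in the series. Compound 3 `Nc1ncn(C/C=C2\OC(=O)C(OCc3ccccc3)=C2OCc2ccccc2)c(=O)n1`, not yet measured, differs from compound 2 by a group of 8 heavy atoms (3 carbon, 4 nitrogen, 1 oxygen; one six-membered aromatic ring with 3 hetero atoms) in place of a group of 8 heavy atoms (3 carbon, 3 nitrogen, 2 oxygen; one six-membered aromatic ring with 3 hetero atoms), on a saturated chain carbon bound to a double-bonded chain carbon. Going by the values given here, no measured step of this kind exists; the entering group is carried by compound 1, which differs from compound 3 in more than this one place. The expected step from compound 2 to compound 3 is a 2.2-fold higher number from compound 2 to compound 3 (0.35 log units; beyond the scatter), toward weaker inhibition and beyond the scatter. Compound 3 is estimated at 55000 nM, between 15000 nM and 200000 nM.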

Compound 3, half-maximal inhibitory concentration: 4670 nM
Beside the measured number, compound 3's estimate is 12-fold (1.07 log units) above it; the whole stated range lies above it.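

In this assay, the place on a saturated chain carbon bound to a double-bonded chain carbon now has its first measured step: the group with 4 nitrogen and 1 oxygen, in place of the group with 3 nitrogen and 2 oxygen, gives a 5.3-fold lower number from compound 2 to compound 3 (0.72 log units; beyond the scatter) and so a stronger inhibitor. The two ring groups are therefore not interchangeable at this place. Nothing measured here gives a cause for the step. Still open, as far as these compounds go, is how a carboxylic acid or a longer chain would read at this place, and whether the same exchange on the core of compound 1 moves the number in the same direction.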